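The compounds below may be only part of what the source reports. "The series", "measured", "known", "first", "only" and "open" are said of these compounds alone.

In a functional assay on UO-31 cells (Homo sapiens) for antiproliferative activity, read by sulforhodamine B assay, with a stated time of 48 h (a lower number here means a stronger inhibitor, a higher number a weaker inhibitor), compound 1 (`O=C(NCCCNc1cc(-c2cn(-c3ccccc3)nc2-c2cccc(O)c2)ccn1)Nc1ccc(F)cc1`) gives 1580 nM and compound 2 (`O=C(NCCCNc1cc(-c2cn(-c3ccccc3)nc2-c2cccc(O)c2)ccn1)Nc1cccc(C(F)(F)F)c1`) gives 2100 nM, so compound 1 has one close neighbour and neither can be ranked above the other. Compound 3 (`COc1cccc(-c2nn(-c3ccccc3)cc2-c2ccnc(NCCCNC(=O)Nc3ccc(F)cc3)c2)c1`) keeps the core of compound 1 and differs at one place, shown by methyl in place of hydrogen on an oxygen on an aromatic ring, which turns 3-hydroxyphenyl into 3-methoxyphenyl.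

Among the measured compounds shown here, the only measured step lies elsewhere. Putting 3-(trifluoromethyl)phenyl in place of 4-fluorophenyl on an amide-type nitrogen gives a 1.3-fold higher number from compound 1 to compound 2 (0.12 log units; within the scatter) and leaves the hydroxy group untouched. For the measured compounds named here, no measured step therefore tests the change to methoxy directly. Going by the values given here, with the small step to compound 2 as the only guide, no step beyond the scatter is expected in this assay, although either direction remains open. The estimated change is a 1.4-fold higher number from compound 1 to compound 3 (0.14 log units; within the scatter) and it carries real uncertainty. For compound 3 the expected value is 2200 nM, with an estimated range from 800 nM to 6000 nM.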

Compound 3, half-maximal inhibitory concentration: 5100 nM
For compound 3 the middle estimate is 2.3-fold (0.37 log units) below the measured one, and the stated range covers the measured number.
By their numbers in this assay, from the lowest: compounds 1 and 2 (each within the scatter of the next); then compound 3.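

In this assay, the change from 3-hydroxyphenyl to 3-methoxyphenyl gives a 3.2-fold higher number from compound 1 to compound 3 (0.51 log units; beyond the scatter). This modest step is the first in the series shown to pass beyond the scatter, so the group on this oxygen on an aromatic ring affects the read-out in a way that the earlier swap on the amide-type nitrogen, a 1.3-fold higher number from compound 1 to compound 2 (0.12 log units; within the scatter), did not reveal. Nothing provided here explains the weaker result, so it stands as an observation for this single pair of compounds.

On these data alone, it remains open how an amino group, a fluorine atom or a longer ethoxy group would read at the same place, and whether a plain phenyl ring with no oxygen there would stay close to compound 1 or move towards compound 3. Also unresolved is whether adding the same methyl to compound 2, which keeps the hydroxy group and carries 3-(trifluoromethyl)phenyl, would produce a step of similar size.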